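This account rests on a few compounds, and the source may have more. Where it says the series, first, only, none or still open, it means among the compounds named here.

Among the measured compounds shown here, in a physicochemical assay for lipophilicity, measured as octanol-water partition (a lower number here means a more polar compound, a higher number a more lipophilic compound), compound 1 `COC(=O)c1cn(C/C=C(/C)CC/C=C(\C)CCC=C(C)C)nn1` gives 5.25 and is the lower of the two compounds measured so far. Compound 2 `CC(C)=CCC/C(C)=C/CC/C(C)=C/Cn1cc(-c2ccccc2)nn1` gives 6.95 in the same measurement, a gap well beyond the scatter. The next compound to be measured, compound 3 `CCCCCc1cn(C/C=C(/C)CC/C=C(\C)CCC=C(C)C)nn1` differs from compound 1 in one place, summarised here as pentyl in place of methoxycarbonyl on an aromatic carbon and put simply as pentyl in place of methoxycarbonyl on an aromatic carbon. The group that leaves contains oxygen, while the group that enters is made of carbon alone. For the measured compounds named here, no measured step of this kind is available, so the only guide is the spread of values. Compound 2 at 6.95 shows how far above compound 1 this small family can reach. In this assay the expected change is an upward a number 2.05 log units higher from compound 1 to compound 3 (beyond the scatter) which would lie beyond the scatter. Compound 3 is estimated at 7.3 with an expected range of 6.7 to 7.9 in this measurement.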

Compound 3, partition coefficient: 7.5
For compound 3 the middle estimate is 0.20 log units below the measured one; the range from low to high includes it.
By their numbers in this assay, from the lowest: compound 1; then compound 2; then compound 3.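

In this assay, placing pentyl instead of methoxycarbonyl on this aromatic carbon gives the first single-place step available for the series (a number 2.25 log units higher from compound 1 to compound 3 (beyond the scatter)). It shows that changing this one group, while the rest of the molecule stays the same, is enough to produce a large shift in the partition read-out. The step removes both oxygen atoms and 2 hydrogen-bond acceptors and adds one more heavy atom, but no supporting measurement here explains why the number moved.

A single step cannot separate the effect of removing the oxygen atoms from that of having a chain of this length at this position. Comparing a propyl or octyl chain, a chain of similar length containing an ether oxygen, or an amine or carboxylic acid on the same carbon would help to tell these possibilities apart.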